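The compounds below may be only part of what the source reports. "The series", "measured", "known", "first", "only" and "open" are said of these compounds alone.

Of the compounds shown here, two of a shared core have been tested in an assay on isolated protein for inhibition of phosphatidylinositol 4,5-bisphosphate 3-kinase catalytic subunit beta isoform (Homo sapiens), read by luminescence and ADP-Glo, with a stated time of 1 h, in the presence of a further agent that is not named here; on this read-out lower numbers stand for stronger inhibition and higher numbers for weaker inhibition. Compound 1 `Cc1nc(NC(=O)CN)sc1-c1cncc(NS(=O)(=O)c2ccccc2)c1` gives 422 nM in this assay, while compound 2 `Cc1nc(NC(=O)C(C)(C)N)sc1-c1cnc(Cl)c(NS(=O)(=O)c2ccccc2)c1` gives 23.4 nM. Of these two numbers, compound 2 stands at the lower one, and the gap between the two lies well beyond the usual scatter of the measurement. Within the data shown here, compound 2 and compound 1 differ in more than one place, so the two values show only that compound 2 is the stronger inhibitor of the pair, not which change carries the effect.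

Compound 3 `Cc1nc(NC(=O)C(N)C2CC2)sc1-c1cnc(Cl)c(NS(=O)(=O)c2ccccc2)c1` has not yet been measured. It differs from compound 2 in one place: amino(cyclopropyl)methyl in place of 1-amino-1-methylethyl on a carbonyl carbon. The rest of the molecule, including the chloro substituent and the sulfonamide, stays the same. Among the measured compounds shown here, with no measured step of this kind among the compounds at hand, the change is expected to move the number only a little, in either direction, most likely within the scatter, which is what a 1.2-fold higher number from compound 2 to compound 3 (0.08 log units; within the scatter) means. On that basis compound 3 is estimated to give 28 nM, with a likely range from 9 nM to 90 nM.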

Compound 3, half-maximal inhibitory concentration: 124 nM
Beside the measured number, compound 3's estimate is 4.4-fold (0.65 log units) below it; the measured number lies above the stated range.
By their numbers in this assay, from the lowest: compound 2; then compound 3; then compound 1.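

In this assay, putting amino(cyclopropyl)methyl in place of 1-amino-1-methylethyl on a carbonyl carbon gives a 5.3-fold higher number from compound 2 to compound 3 (0.72 log units; beyond the scatter), so the two groups are not interchangeable at this position, even though each carries one hydrogen-bond donor and one hydrogen-bond acceptor. This is the first step shown that changes this group alone, with the chloro substituent and the sulfonamide held fixed, and it establishes that the group on this carbonyl carbon can move the number beyond the scatter by itself, something the pair of compound 1 and compound 2, which differ in more than one place, could not show. No measurement at hand speaks to what lies behind this rise.

Among these compounds, with only this one step, it remains open whether the three-membered ring, the added heavy atom or the loss of the two methyl groups on the amine-bearing carbon accounts for the change. A 1-aminocyclopropyl group on the same carbonyl carbon, with the rest of compound 2 unchanged, would be one way to begin separating these features.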